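Sulfamoylurea variation at the sulfonyl nitrogen

This account rests on a few compounds, and the source may have more. Where it says the series, first, only, none or still open, it means among the compounds named here.

The measured compounds:
compound 1, `CC(C)c1cccc(C(C)C)c1NC(=O)NS(=O)(=O)N(C)C`, with 3900 nM
compound 2, `CCCN(CCC)S(=O)(=O)NC(=O)Nc1c(C(C)C)cccc1C(C)C`, with 1100 nM

Both share the same core, a diisopropylphenyl urea joined to a sulfamoyl group, and differ only in the amine on the sulfonyl sulfur. In an assay on liver for inhibition of sterol O-acyltransferase 1 (Rattus norvegicus), using microsomes (a higher number here means a weaker inhibitor, a lower number a stronger inhibitor), compound 1 gives 3900 nM, while compound 2 gives 1100 nM. For the measured compounds named here, the single step between them, a 3.5-fold lower number from compound 1 to compound 2 (0.55 log units; beyond the scatter), is the only one known and is of modest size. Going by the values given here, compound 2 therefore stands with the lowest of the two numbers, with compound 1 as its only neighbour.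

Compound 3, `CCCCCCNS(=O)(=O)NC(=O)Nc1c(C(C)C)cccc1C(C)C`, carries the change (hexylamino in place of dipropylamino on a sulfonyl sulfur). The two nitrogen substituents are thus rearranged into a single chain and a hydrogen appears on that nitrogen. Among the compounds with values here, the one step bearing on this position, from compound 1 to compound 2, went to a lower number when the alkyl groups grew; nothing is known about a chain of the same size arranged differently, or about a hydrogen on that nitrogen. A step of no more than the scatter is expected, a 1.2-fold lower number from compound 2 to compound 3 (0.09 log units; within the scatter), in either direction. Compound 3 is estimated at 900 nM in this assay, with a range from 300 nM to 3000 nM.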

Compound 3, half-maximal inhibitory concentration: 8100 nM
For compound 3 the middle estimate is 9.0-fold (0.95 log units) below the measured one, and the stated range ends below it.
By their numbers in this assay, from the lowest: compound 2; then compound 1; then compound 3.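

In this assay, the arrangement of the amine on the sulfonyl sulfur matters and not only its size: hexylamino and dipropylamino both have 7 heavy atoms, yet the exchange gives a 7.4-fold higher number from compound 2 to compound 3 (0.87 log units; beyond the scatter) and so reverses the gain seen with the larger alkyl groups. Compared with the smaller dimethylamino group, hexylamino also gives a 2.1-fold higher number from compound 1 to compound 3 (0.32 log units; beyond the scatter) and therefore does not continue the earlier trend, with compound 3 going against the idea that more alkyl carbon on this nitrogen lowers the number. The change from two chains to one also adds a hydrogen-bond donor, but nothing measured here accounts for the rise.

The compounds shown cannot separate the single chain from the hydrogen on the nitrogen, since both differences arrive together in compound 3. A methyl(hexyl)amino group would keep the long chain without that hydrogen, a propylamino group would keep the hydrogen on a shorter chain, and a piperidine ring would tie two chains together, so each would help to tell these effects apart.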